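A Larger Amine in Place of a Small Amino Group

This account rests on a few compounds, and the source may have more. Where it says the series, first, only, none or still open, it means among the compounds named here.

Measured so far in a functional assay on HEK293 cells for activation of melanin-concentrating hormone receptor 1 (Rattus norvegicus), read by inositol phosphate accumulation; a lower number here means that less compound is needed, a higher number that more compound is needed for the effect:
compound 1, `CN(c1ccc2cc(NC(=O)CCc3ccc(C(F)(F)F)cc3)ccc2n1)C1CCCCC1`, gives 1200 nM;
compound 2, `O=C(CCc1ccc(C(F)(F)F)cc1)Nc1ccc2nc(N3CCC(c4ccccc4)C3)ccc2c1`, gives 1770 nM;
compound 3, `Nc1ccc2cc(NC(=O)CCc3ccc(C(F)(F)F)cc3)ccc2n1`, gives 720 nM.

Compound 3, which carries a plain amino group on the shared core, has the lowest of the three numbers. The step from its nearest neighbour is a 1.7-fold lower number from compound 1 to compound 3 (0.22 log units; within the scatter), so the two cannot be told apart with confidence. The step from the other compound is a 2.5-fold lower number from compound 2 to compound 3 (0.39 log units; beyond the scatter), a modest but real difference.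

Compound 4, `O=C(CCc1ccc(C(F)(F)F)cc1)Nc1ccc2nc(N3CC4CC3CO4)ccc2c1`, differs from compound 3 in one place: a group of 7 heavy atoms (5 carbon, 1 nitrogen, 1 oxygen; 2 five-membered non-aromatic rings with 1 hetero atom each) in place of one nitrogen atom, on an aromatic carbon. The two measured steps that bear on this change are those in which the same amino group stands against a group of more atoms on the same aromatic carbon: a 1.7-fold lower number from compound 1 to compound 3 (0.22 log units; within the scatter) and a 2.5-fold lower number from compound 2 to compound 3 (0.39 log units; beyond the scatter). Both point the same way, with the amino compound giving the lower number, once within the scatter and once modestly beyond it. On that basis compound 4 is expected to give a somewhat higher number than compound 3, an expected step of a 1.7-fold higher number from compound 3 to compound 4 (0.22 log units; within the scatter), which may still fall within the scatter. Compound 4 is therefore estimated at 1200 nM in this assay, with a likely range from 500 nM to 3000 nM.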

Compound 4, half-maximal effective concentration: 70 nM
Compound 4: the middle estimate sits 17-fold (1.23 log units) above what was measured; measured number below the stated range.
By their numbers in this assay, from the lowest: compound 4; then compounds 3, 1 and 2 (each within the scatter of the next, the first and the last beyond it).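

In this assay, for the compounds shown here, the earlier compounds gave no sign that a larger group on this aromatic carbon, next to the ring nitrogen, could improve on amino, yet the group with two five-membered non-aromatic rings brings a large drop (a 10-fold lower number from compound 3 to compound 4 (1.01 log units; beyond the scatter)). The same group also stands far from the two other larger groups, with large steps against the cyclohexyl(methyl)amino group (a 17-fold lower number from compound 1 to compound 4 (1.23 log units; beyond the scatter)) and the 3-phenylpyrrolidin-1-yl group (a 25-fold lower number from compound 2 to compound 4 (1.40 log units; beyond the scatter)). A larger group on this carbon is therefore not a penalty in itself: among these four compounds, the number depends on which group enters, and a count of heavy atoms alone does not put them in order.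

Compound 4 is the only one of the four whose changing group holds an oxygen, so the compounds shown cannot separate the part played by that oxygen from that of the two-ring framework, and neither a plain morpholine ring nor the same framework with carbon in place of the oxygen is among them. No measurement available here explains the size of this change.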